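The source may hold more compounds than are shown below. What is called first, only, known or untested is meant among the compounds shown, and "the series" means these compounds.

Compound 1 `Cc1cc(C)c(S(=O)(=O)N2CCN(C3CN4CCC3CC4)CC2)c(C)c1` gives 84 nM.
Compound 2 `CC1CCN(C2CCN(S(=O)(=O)c3ccc(F)cc3F)CC2)CC1` gives 102 nM.
Compound 3 `Cc1ccc(-c2ccccc2S(=O)(=O)N2CCC(N3CCC(C)CC3)CC2)cc1` gives 366 nM.

These three values come from a functional assay on DLD-1 cells (Homo sapiens) for antiproliferative activity, read by CellTiter-Glo, with a stated time of 72 h; a higher number here means a weaker inhibitor, a lower number a stronger inhibitor. Among them compound 2 stands with the second highest number. Its nearest neighbour is compound 1, whose number is slightly lower but within the usual scatter of repeated measurements, so the two cannot be told apart. Its furthest neighbour is compound 3, whose number is higher by a margin that lies beyond the scatter, so compound 3 is the weaker inhibitor of that pair.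

Compound 4 `CC1CCN(C2CCN(S(=O)(=O)c3cnc(Cl)s3)CC2)CC1` is the untested compound. It differs from compound 2 in one place only: 2-chloro-1,3-thiazol-5-yl in place of 2,4-difluorophenyl on a sulfonyl sulfur. The sulfonamide and the rest of the molecule are kept. For the measured compounds named here, no two of the measured compounds differ in a single place, so there is no measured step to lean on for this kind of swap. The shared piperidinyl-piperidine part of compound 2 and compound 4 is unchanged, and the change is confined to the group on the sulfonyl sulfur, so the expected step in this assay is small, without a clear direction, and likely within the scatter. The expected value for compound 4 is 150 nM, with a range from 50 nM to 450 nM. That estimate means a step of a 1.5-fold higher number from compound 2 to compound 4 (0.17 log units; within the scatter).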

Compound 4, half-maximal inhibitory concentration: 1800 nM
Beside the measured number, compound 4's estimate is 12-fold (1.08 log units) below it, and the stated range ends below it.
By their numbers in this assay, from the lowest: compounds 1 and 2 (each within the scatter of the next); then compound 3; then compound 4.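

In this assay, the group on the sulfonyl sulfur proves to matter a great deal: with the rest of the molecule kept, putting 2-chloro-1,3-thiazol-5-yl in place of 2,4-difluorophenyl gives an 18-fold higher number from compound 2 to compound 4 (1.25 log units; beyond the scatter). For this pair, then, one aromatic ring cannot simply stand in for another at this position, although the swap changes several things at once: a six-membered aromatic ring of carbon only gives way to a five-membered aromatic ring with 2 hetero atoms, the two fluorine atoms leave, a chlorine enters, and the group goes from 0 hydrogen-bond acceptors to 2 hydrogen-bond acceptors. No measurement at hand bears on the reason for the step, and which of these differences counts remains unknown.

The compounds shown leave open whether the loss belongs to the thiazole ring itself or to its chlorine, a question that a thiazole carrying a methyl group in place of the chlorine, or a plain phenyl group on the same sulfur, could help to separate. They also leave open whether the same swap would cost as much on the core of compound 1.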